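A Larger Ether Side Chain on the Shared Core

The compounds below may be only part of what the source reports. "The series", "measured", "known", "first", "only" and "open" are said of these compounds alone.

Of the compounds shown here, two with the shared core have been measured in an assay on brain for displacement of a labelled ligand from Adrenergic receptor alpha-1 (Rattus norvegicus); on this read-out higher numbers stand for weaker inhibition and lower numbers for stronger inhibition. Compound 1, `CCOCCOC1CCN(c2nc(N)c3cc(OC)c(OC)cc3n2)CC1`, gives 1.81 nM in this assay. Compound 2, `COc1cc2nc(N3CCC(OCC(C)OC)CC3)nc(N)c2cc1OC`, gives 1.41 nM in this assay. Going by the values given here, the single measured step, a 1.3-fold lower number from compound 1 to compound 2 (0.11 log units; within the scatter), exchanges one small ether chain for another and stays within the scatter. Compound 2 thus holds the lower of the two numbers, yet the gap to compound 1 does not truly separate them.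

Compound 3, `CCOCC(OC1CCN(c2nc(N)c3cc(OC)c(OC)cc3n2)CC1)c1ccccc1`, remains unmeasured. Relative to compound 2 the change is 2-ethoxy-1-phenylethyl in place of 2-methoxypropyl on an oxygen on a saturated carbon. The step from compound 1 to compound 2 is the only one touching the same place, and it was small; it compares two chains of similar size and offers nothing direct about bringing in a six-membered aromatic ring. On that footing no step beyond the scatter is expected in either direction, though the much larger group widens the uncertainty. Compound 3 is therefore estimated at 2.5 nM, with a range from 0.7 nM to 9 nM. The expected step, a 1.8-fold higher number from compound 2 to compound 3 (0.25 log units; within the scatter), would leave compound 3 near compound 2 in this assay.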

Compound 3, inhibition constant: 10 nM
The estimate for compound 3 lay 4.0-fold (0.60 log units) below the measured number; the measured number lies above the stated range.
By their numbers in this assay, from the lowest: compounds 2 and 1 (each within the scatter of the next); then compound 3.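

Going by these compounds alone, on an oxygen on a saturated carbon whose other neighbours are: saturated ring carbon, the small ether chains of compounds 1 and 2 had not been told apart, but in this assay the 2-ethoxy-1-phenylethyl group brings the first change here that lies beyond the scatter (a 7.1-fold higher number from compound 2 to compound 3 (0.85 log units; beyond the scatter)). Within the data shown here, the cleanest reading comes from the comparison with compound 1, where the only change is phenyl in place of hydrogen on a saturated chain carbon bound to an oxygen on a saturated carbon and a saturated chain carbon (a 5.5-fold higher number from compound 1 to compound 3 (0.74 log units; beyond the scatter)), so one six-membered aromatic ring on this chain is enough to raise the number, though only modestly, and compound 3 still gives 10 nM. Nothing shown here accounts for this rise.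

The compounds shown leave open whether the rise follows the aromatic ring itself or simply the larger group, a question that a cyclohexyl group on the same chain carbon would address. Also open, as far as these compounds go, is how a chain ending in an amine or a carboxylic acid would read in this assay.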